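Compound 1 to compound 3: acetamido in place of methoxy

A few compounds are considered here, and "the series" means these few. Any claim that something is new, unique, unknown or untested is made for them only; others in the source may bear on it.

For the measured compounds named here, in a functional assay on HeLa cells (Homo sapiens) for cytotoxicity, read by resazurin assay, with a stated time of 72 h (on this read-out higher numbers stand for weaker inhibition and lower numbers for stronger inhibition), compound 1 (`CCOC(=S)SCC(=O)c1ccc(OC)cc1`) gives 4640 nM, the lower of the two numbers so far. Compound 2 (`CCOC(=O)SCC(=O)c1ccc(OC)cc1`) gives 18500 nM. Going by the values given here, the only measured step is a 4.0-fold higher number from compound 1 to compound 2 (0.60 log units; beyond the scatter). It concerns the group on the sulfur, not the substituent on the aromatic ring.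

Compound 3 (`CCOC(=S)SCC(=O)c1ccc(NC(C)=O)cc1`) keeps the sulfur group of compound 1 and carries acetamido in place of methoxy on an aromatic carbon. Among the compounds with values here, no measured pair changes this place, so the data give no direct size for the step. The step to compound 2, a 4.0-fold higher number from compound 1 to compound 2 (0.60 log units; beyond the scatter), serves only as a rough scale for what one change can do in this series. With compound 1 at 4640 nM holding the lower number, a modest step to a higher number in this assay is expected, though on thin evidence. The estimated step is a 2.2-fold higher number from compound 1 to compound 3 (0.33 log units; beyond the scatter). Compound 3 is expected at 10000 nM, with an estimated range of 3000 nM to 32000 nM.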

Compound 3, half-maximal inhibitory concentration: 3610 nM
Compound 3: middle estimate off by 2.8-fold (0.44 log units), on the high side; low and high end bracket the measured number.
By their numbers in this assay, from the lowest: compounds 3 and 1 (each within the scatter of the next); then compound 2.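

In this assay the only measured change at this ring position, acetamido in place of methoxy on an aromatic carbon, gives a step within the scatter (a 1.3-fold lower number from compound 1 to compound 3 (0.11 log units; within the scatter)), so the position has now been shown to accept this exchange with no measurable shift in the number. The substituent goes from 0 hydrogen-bond donors in methoxy to 1 hydrogen-bond donor in acetamido without leaving the scatter, whereas the change on the sulfur (a 4.0-fold higher number from compound 1 to compound 2 (0.60 log units; beyond the scatter)) lies beyond it. No measurement at hand accounts for this result.

On these data alone, whether a free amine, a carboxylic acid or a longer acyl chain in this same place would also stay within the scatter of compound 1 remains open, and a single exchange gives no trend for the position. Also open, as far as these compounds go, is whether acetamido would give a similar result when combined with the group on the sulfur of compound 2.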